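Moving the ethyl group around the amide ring

The compounds below may be only part of what the source reports. "The series", "measured", "known", "first", "only" and "open" are said of these compounds alone.

Among the three compounds measured so far in a functional assay on MCF7 cells (Homo sapiens) for antiproliferative activity, read by MTT assay, with a stated time of 72 h (on this read-out lower numbers stand for stronger inhibition and higher numbers for weaker inhibition), compound 1 `CCc1ccccc1C(=O)Nc1ccc2nc(N3CCN(CC)CC3)cc(C)c2c1` stands highest, at 15800 nM. Compound 2 `Cc1cc(N2CCN(C)CC2)nc2ccc(NC(=O)c3ccc(Cl)c(Cl)c3)cc12` gives 3000 nM, and compound 3 `CCN(CC)CCNc1cc(C)c2cc(NC(=O)c3ccc(Cl)c(Cl)c3)ccc2n1` gives 1420 nM. For the measured compounds named here, the only step that differs in one place runs between those two: a 2.1-fold lower number from compound 2 to compound 3 (0.32 log units; beyond the scatter). That step alters the amine on the shared core, not the aryl amide, so it says nothing directly about the change now in question.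

Compound 4 `CCc1ccc(C(=O)Nc2ccc3nc(N4CCN(CC)CC4)cc(C)c3c2)cc1` differs from compound 1 only in the aryl group attached to the carbonyl: 4-ethylphenyl in place of 2-ethylphenyl on a carbonyl carbon. Going by the values given here, no measured pair isolates such a move, and compounds 2 and 3 carry a dichlorophenyl that differs from compound 1 in more than one place, so their lower numbers cannot be pinned on the ring pattern alone. The expectation is therefore a modest improvement with wide uncertainty: compound 4 is estimated at 6000 nM, within 2000 nM to 20000 nM, a step of a 2.6-fold lower number from compound 1 to compound 4 (0.42 log units; beyond the scatter).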

Compound 4, half-maximal inhibitory concentration: 3060 nM
The estimate for compound 4 lay 2.0-fold (0.29 log units) above the measured number, within the range that was stated.
By their numbers in this assay, from the lowest: compound 3; then compounds 2 and 4 (each within the scatter of the next); then compound 1.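

Compound 1 and compound 4 contain the same atoms, and only the attachment point of the ethyl group differs. Replacing 2-ethylphenyl with 4-ethylphenyl on a carbonyl carbon gives a 5.2-fold lower number from compound 1 to compound 4 (0.71 log units; beyond the scatter) in this assay. This is the first single-change pair shown that alters the aryl group on the carbonyl rather than the amine on the shared core, and it shows that the ethyl group's location alone can shift the result beyond the scatter, with no atom added or removed; no measurement here gives a reason for the shift.

As far as these compounds go, it remains open whether the same move would give a step of similar size with (2-(diethylamino)ethyl)amino on the core. Also open, from the compounds shown here alone, is how a propyl chain or a carboxylic acid in place of the ethyl group would read out.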